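Cyclopropylamino analogue in the cytotoxicity series

The source may report more compounds than this note shows. Statements on the series, on what has been measured and on what is new or still open speak of the compounds shown alone.

The shared core of compound 1 `CNc1nc(N)nc2c1ncn2/C=C1/CC1(CO)CO` runs through the whole set. In an ADME assay on MOLT-3 cells (Homo sapiens) for cytotoxicity, with a stated time of 7 days (on this read-out higher numbers stand for lower toxicity in this test and lower numbers for higher toxicity in this test), compound 1 gives > 20000 nM, which is a limit of the assay rather than a number. Compound 2 `Nc1nc(OCC(F)(F)F)c2ncn(/C=C3/CC3(CO)CO)c2n1` gives > 20000 nM in this assay, again a limit. Compound 3 `Nc1nc(NCc2ccccc2)c2ncn(/C=C3/CC3(CO)CO)c2n1` gives > 20000 nM in this assay, also a limit. The steps a step that the two limits leave unreadable from compound 1 to compound 2, a step that the two limits leave unreadable from compound 1 to compound 3 and a step that the two limits leave unreadable from compound 2 to compound 3 cannot be sized because of the limit of > 20000 nM in this assay, at which 3 of the 3 values shown sit.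

Compound 4 `Nc1nc(NC2CC2)c2ncn(/C=C3/CC3(CO)CO)c2n1` differs from compound 1 in one place: cyclopropyl in place of methyl on a nitrogen on an aromatic ring. Within the data shown here, none of the measured steps is readable, so no direction can be taken from them; what the three measured compounds share is that each substituent at this position left the read-out at the limit. For compound 4 the step that the limit leaves unreadable from compound 1 to compound 4 is expected, meaning no readable change. Compound 4 is therefore estimated at 25000 nM, within 15000 nM to 60000 nM, most likely reported again as a limit.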

Compound 4, half-maximal cytotoxic concentration: > 20000 nM
Compound 4: no number, only a limit (the forecaster's own chance of this, stated with the estimate: 85%); the middle value does not contradict the limit.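

Compound 4 adds no readable step: its steps from compound 1, compound 2 and compound 3 cannot be read, because all four compounds sit at one limit: the limit of > 20000 nM in this assay, at which 4 of the 4 values shown sit.

The compounds shown leave open whether methylamino, 2,2,2-trifluoroethoxy, benzylamino and cyclopropylamino differ at all in cytotoxicity.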